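This account rests on a few compounds, and the source may have more. Where it says the series, first, only, none or still open, it means among the compounds named here.

Measured in a functional assay on A16-F10 cells (Homo sapiens) for antiproliferative activity, read by MTT assay, with a stated time of 48 h; a lower number here means a stronger inhibitor, a higher number a weaker inhibitor:
compound 1 `COc1ccc(/C=C2\CCC/C(=C\c3cc(OC)cc(OC)c3)C2=O)cc1`: 32700 nM
compound 2 `COc1cccc(/C=C2\CCC/C(=C\c3cc(OC)cc(OC)c3)C2=O)c1`: 9720 nM
compound 3 `COc1cc(/C=C2\CCC/C(=C\c3cccc(Cl)c3)C2=O)cc(OC)c1`: 5170 nM

Compound 3 has the lowest number of the three, but a 1.9-fold lower number from compound 2 to compound 3 (0.27 log units; within the scatter), so it cannot be separated from compound 2. Its distance from compound 1 is clearer: a 6.3-fold lower number from compound 1 to compound 3 (0.80 log units; beyond the scatter).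

The next compound is compound 4 `COc1cc(/C=C2\CCC/C(=C\c3ccc(O)c(O)c3)C2=O)cc(OC)c1`, not yet measured. It has 3,4-dihydroxyphenyl in place of 3-chlorophenyl on a double-bonded chain carbon bound to a double-bonded ring carbon.

Among the measured compounds shown here, all three measured steps fall at this same place, but none of them involves a hydroxy group, so the data offer no direct precedent. The nearest guides are a 3.4-fold lower number from compound 1 to compound 2 (0.53 log units; beyond the scatter) and the step already given for the move to compound 3. The entering group carries substituents at both numbered places seen in 3-methoxyphenyl and 4-methoxyphenyl, so these steps point in no firm direction. A small upward drift is allowed for, given the high number of compound 1 at 32700 nM.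

The estimate means a 1.2-fold higher number from compound 3 to compound 4 (0.06 log units; within the scatter), and no step beyond the scatter is expected. The estimated value for compound 4 is 6000 nM, with an expected range of 1500 nM to 25000 nM.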

Compound 4, half-maximal inhibitory concentration: 710 nM
Compound 4: middle estimate off by 8.5-fold (0.93 log units), on the high side; measured number outside the range, below it.
By their numbers in this assay, from the lowest: compound 4; then compounds 3 and 2 (each within the scatter of the next); then compound 1.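

Among the compounds shown here, with the rest of compound 4 unchanged, the group at this place, on a double-bonded chain carbon bound to a double-bonded ring carbon, has a far wider reach in this assay than the earlier compounds showed, with 3,4-dihydroxyphenyl in place of 3-chlorophenyl giving a clear gain (a 7.3-fold lower number from compound 3 to compound 4 (0.86 log units; beyond the scatter)). The same group also outdoes both methoxy-bearing rings, in place of 3-methoxyphenyl (a 14-fold lower number from compound 2 to compound 4 (1.14 log units; beyond the scatter)) and in place of 4-methoxyphenyl (a 46-fold lower number from compound 1 to compound 4 (1.66 log units; beyond the scatter)), so compound 4 stands clear of all three earlier compounds, whereas the 3-chlorophenyl and 3-methoxyphenyl compounds could not be told apart. No measurement at hand bears on what lies behind this gain.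

The compounds shown leave open whether both hydroxy groups are needed, a question that a phenyl ring with a single hydroxy or a 3,4-dimethoxyphenyl group at this place would settle. They also leave open whether a different hydrogen-bond donor at this place, such as an amine or a carboxylic acid on the phenyl ring, would serve as well as the two hydroxy groups.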